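Fluoro for methoxy on a bromo-to-methyl stilbene oxime

This account rests on a few compounds, and the source may have more. Where it says the series, first, only, none or still open, it means among the compounds named here.

A small series of three oxime compounds was examined in an ADME assay on cells (Mus musculus, strain Balb/c) for cytotoxicity, read by MTT assay, with a stated time of 48 h; a higher number here means that more compound is tolerated, a lower number that less compound is tolerated. Compound 1 `O/N=C(\C=C\c1ccc(F)cc1)c1ccc(Br)cc1` gives 20300 nM in this assay. Compound 2 `COc1ccc(/C=C/C(=N\O)c2ccc(Br)cc2)cc1` gives 23700 nM in this assay. Compound 3 `COc1ccc(/C=C/C(=N\O)c2ccc(C)cc2)cc1` gives 117000 nM in this assay, the highest of the three numbers, and its steps to compound 2 and to compound 1 are both beyond the scatter.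

Two single changes connect the measured compounds. The first is fluoro in place of methoxy on an aromatic carbon, and its step was a 1.2-fold lower number from compound 2 to compound 1 (0.07 log units; within the scatter). The second is methyl in place of bromo on an aromatic carbon, and its step was a 4.9-fold higher number from compound 2 to compound 3 (0.69 log units; beyond the scatter).

Compound 4 `Cc1ccc(C(/C=C/c2ccc(F)cc2)=N/O)cc1` has not yet been measured in this assay. Its core differs from that of compound 2 by methyl in place of bromo on an aromatic carbon as shown above, and it differs from compound 3 by fluoro in place of methoxy on an aromatic carbon. This is the same change as that from compound 2 to compound 1, in the same place, and it occurs twice among the compounds shown. Since that earlier step was within the scatter, compound 4 is expected to sit close to compound 3, with an estimated step of a 1.2-fold lower number from compound 3 to compound 4 (0.07 log units; within the scatter) in this assay. The estimate for compound 4 in this assay is 100000 nM, expected to fall between 50000 nM and 200000 nM, resting on the value of compound 3, 117000 nM, and on the earlier step of a 1.2-fold lower number from compound 2 to compound 1 (0.07 log units; within the scatter).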

Compound 4, half-maximal cytotoxic concentration: 13200 nM
Compound 4: middle estimate off by 7.6-fold (0.88 log units), on the high side, and the stated range ends above it.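

With methyl on the shared core, fluoro in place of methoxy gave an 8.9-fold lower number from compound 3 to compound 4 (0.95 log units; beyond the scatter) in this assay, whereas with fluoro already present, methyl in place of bromo gave a 1.5-fold lower number from compound 1 to compound 4 (0.19 log units; within the scatter). Fluoro in place of methoxy therefore did not carry from one core to the other in this assay: the same change on two cores in this assay, a 1.2-fold lower number (0.07 log units; within the scatter) from compound 2 to compound 1 and an 8.9-fold lower number (0.95 log units; beyond the scatter) from compound 3 to compound 4, 7.6-fold (0.88 log units) apart, beyond the scatter of two such steps. Methyl in place of bromo did not carry either, but both comparisons rest on the same four compounds, so they show a single case in which the outcome of one change depended on the group at the other end of the molecule, and they show neither why this happened nor whether it would recur with other pairs of groups: the same change on two cores in this assay, a 4.9-fold higher number (0.69 log units; beyond the scatter) from compound 2 to compound 3 and a 1.5-fold lower number (0.19 log units; within the scatter) from compound 1 to compound 4, 7.6-fold (0.88 log units) apart, beyond the scatter of two such steps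

The compounds shown leave open how this assay would respond if an amine, a carboxylic acid or a longer chain, such as propyl, stood in place of the methyl or bromo group. They also leave open whether chloro in place of fluoro would follow compound 4 or compound 3, and whether a carbonyl in place of the oxime would preserve the dependence seen here.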